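Nitro for methylsulfonyl on the benzoyl of compound 3

A few compounds are considered here, and "the series" means these few. Any claim that something is new, unique, unknown or untested is made for them only; others in the source may bear on it.

Compound 1: `CNC(=O)c1cccc(S(=O)(=O)Oc2ccc(-c3cncn3C3CCN(C(=O)c4ccc(Cl)c(C(F)(F)F)c4)CC3)cc2)c1`, 112 nM
Compound 2: `CS(=O)(=O)c1ccc(C(=O)N2CCC(n3cncc3-c3ccc(OS(=O)(=O)c4cccc(C#N)c4)cc3)CC2)cc1`, 143 nM
Compound 3: `CS(=O)(=O)c1ccc(C(=O)N2CCN(c3cc(=O)[nH]c(=O)n3Cc3ccc(OS(=O)(=O)c4cccc5cnccc45)cc3)CC2)cc1`, 44 nM

Of the compounds shown here, three have been measured in an assay on HEK293 cells for antagonist activity at P2X purinoceptor 7 (Homo sapiens), read by fluorescence, with a stated time of 2 h; a lower number here means a stronger inhibitor, a higher number a weaker inhibitor. Compound 3 stands lowest of the three numbers: its nearest neighbour is compound 1, whose number is higher by a margin beyond the scatter, and furthest is compound 2, also beyond the scatter. Compound 3 is therefore the strongest inhibitor among the three measured.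

Compound 4 is `O=C(c1ccc([N+](=O)[O-])cc1)N1CCN(c2cc(=O)[nH]c(=O)n2Cc2ccc(OS(=O)(=O)c3cccc4cnccc34)cc2)CC1`. It differs from compound 3 in one place: nitro in place of methylsulfonyl on an aromatic carbon. Among the measured compounds shown here, no step between two measured compounds isolates this exchange, so the expectation rests on the single measured value of compound 3 alone. Because compound 3 gives 44 nM, and the exchange keeps the same count of hydrogen-bond acceptors and donors on the same aromatic carbon, the step is expected to be small, with a slight tilt toward a higher number. Compound 4 is estimated at 65 nM, in a range from 25 nM to 170 nM. This amounts to an expected step of a 1.5-fold higher number from compound 3 to compound 4 (0.17 log units; within the scatter), not clearly beyond the scatter.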

Compound 4, half-maximal inhibitory concentration: 27 nM
The estimate for compound 4 lay 2.4-fold (0.38 log units) above the measured number, and the stated range covers the measured number.
By their numbers in this assay, from the lowest: compounds 4 and 3 (each within the scatter of the next); then compounds 1 and 2 (each within the scatter of the next).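

In this assay, among the compounds shown here, going from 4-(methylsulfonyl)phenyl to 4-nitrophenyl gives a 1.6-fold lower number from compound 3 to compound 4 (0.21 log units; within the scatter) and is the only step here that isolates a single change. At this aromatic carbon, nitro can therefore stand in for methylsulfonyl with no difference that can be told from the scatter, although the entering group has one heavy atom fewer and lacks the sulfur and the methyl carbon. No measurement offered here bears on the reason for this result.

From the compounds shown here alone, the two groups both carry hydrogen-bond acceptors and no donors, so what an amine or a carboxylic acid on this carbon would give remains open. Also open, going by these compounds, is whether nitro would read the same on the core of compound 2, which carries the same methylsulfonyl group.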